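The source may hold more compounds than are shown below. What is called first, only, known or untested is meant among the compounds shown, and "the series" means these compounds.

Measured compounds:
- compound 1 `O=C(CN1CCN(c2nnc(Cc3ccncc3)c3ccccc23)CC1)Nc1ccc(F)c(F)c1`: 0.84 nM
- compound 2 `O=C(CN1CCN(c2nnc(Cc3ccncc3)c3ccccc23)CC1)Nc1ccc(F)c(Cl)c1`: 4 nM
- compound 3 `O=C(CN1CCN(c2nnc(Cc3ccccc3)c3ccccc23)CC1)Nc1ccc(F)c(Cl)c1`: 7360 nM

These three compounds were tested in a functional assay on MDA-MB-231 cells (Homo sapiens) for cytotoxicity, read by MTT assay, with a stated time of 72 h; on this read-out higher numbers stand for weaker inhibition and lower numbers for stronger inhibition. Compound 3 gives the highest number of the three, so it is the weakest of them: the step of a 1800-fold higher number from compound 2 to compound 3 (3.26 log units; beyond the scatter) lies far beyond the scatter, and the gap to compound 1 is larger still. Compound 4 `O=C(CN1CCN(c2nnc(Cc3ccccc3)c3ccccc23)CC1)Nc1cc(C(F)(F)F)ccc1Cl` differs from compound 3 only at the amide-type nitrogen: 2-chloro-5-(trifluoromethyl)phenyl in place of 3-chloro-4-fluorophenyl on an amide-type nitrogen.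

Going by the values given here, only one measured step touches this part of the molecule. The step of a 4.8-fold higher number from compound 1 to compound 2 (0.68 log units; beyond the scatter) exchanged one halogen for another on the ring attached to the amide nitrogen and shifted the number only modestly. The step of a 1800-fold higher number from compound 2 to compound 3 (3.26 log units; beyond the scatter) concerns a different region and says nothing about this ring. Among the compounds with values here, the change from compound 3 to compound 4 is larger than a single halogen swap, since both the pattern and the groups on the ring differ, so no measured step covers it closely.

Within the data shown here, for compound 4 a modest step is expected, a 1.6-fold higher number from compound 3 to compound 4 (0.21 log units; within the scatter), most likely toward a higher number because compound 3 already gives 7360 nM and the only change seen on this ring, a 4.8-fold higher number from compound 1 to compound 2 (0.68 log units; beyond the scatter), moved the number upward. Compound 4 is therefore estimated at 12000 nM, within a range from 3000 nM to 50000 nM.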

Compound 4, half-maximal inhibitory concentration: 19500 nM
Compound 4: middle estimate off by 1.6-fold (0.21 log units), on the low side, and the stated range covers the measured number.
By their numbers in this assay, from the lowest: compound 1; then compound 2; then compound 3; then compound 4.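

In this assay, replacing the ring on the amide-type nitrogen gives a 2.6-fold higher number from compound 3 to compound 4 (0.42 log units; beyond the scatter), a real but modest change. This ring swap adds heavy atoms and changes both the substituents and their pattern, yet its step remains much smaller than a 1800-fold higher number from compound 2 to compound 3 (3.26 log units; beyond the scatter), so this position shows more tolerance here than the phenyl-for-pyridin-4-yl change did. Both measured changes on this ring raised the number, the earlier one being a 4.8-fold higher number from compound 1 to compound 2 (0.68 log units; beyond the scatter), but they start from different compounds, and no evidence available here explains the rise.

Going by these compounds alone, the single step cannot show how much comes from the trifluoromethyl group and how much from the altered chlorine pattern. Also open, on these data alone, are how 2-chloro-5-(trifluoromethyl)phenyl would behave alongside pyridin-4-yl, and how a ring bearing a methoxy group or an amine would compare.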